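Methoxy added to a thiosemicarbazone: one step, two settings

The source may report more compounds than this note shows. Statements on the series, on what has been measured and on what is new or still open speak of the compounds shown alone.

Compound 1 `CC1=CC[C@H](C(C)(C)NC(=S)N/N=C/c2ccc(O)cc2)CC1` > 100000 nM
Compound 2 `COc1cc(/C=N/NC(=S)NC(C)(C)[C@H]2CC=C(C)CC2)ccc1O` < 700 nM
Compound 3 `CC1=CC[C@H](C(C)(C)NC(=S)N/N=C(\C)c2ccccc2)CC1` > 100000 nM

In a functional assay on HT-29 cells (Homo sapiens) for inhibition, read by sulforhodamine B assay, with a stated time of 48 h (on this read-out lower numbers stand for stronger inhibition of growth and higher numbers for weaker inhibition of growth), compound 1 gives > 100000 nM, which is a limit of the assay. Compound 2 gives < 700 nM in this assay, again a limit. Between them lies one change, (methoxy in place of hydrogen on an aromatic carbon), and the step is an at least 140-fold lower number from compound 1 to compound 2 (2.15 log units; beyond the scatter), though its true size is open because the limit of < 700 nM in this assay, at which 1 of the 3 values shown sits, and the limit of > 100000 nM in this assay, at which 2 of the 3 values shown sit, bound it on both sides.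

Compound 3 gives > 100000 nM in this assay, a limit. The difference between the core of compound 3 and that of compound 1 is not broken down here. Compound 4 `COc1ccc(/C(C)=N/NC(=S)NC(C)(C)[C@H]2CC=C(C)CC2)cc1` carries the same kind of change as compound 2, (methoxy in place of hydrogen on an aromatic carbon), but around the place it differs: in compound 2 the methoxy sits ortho to a hydroxy group and meta to a large group, in compound 4 para to a large group.

Resting only on the step from compound 1 to compound 2, compound 4 is expected to move by an at least 5.0-fold lower number from compound 3 to compound 4 (0.69 log units; beyond the scatter). Compound 4 is estimated at 20000 nM, between 2000 nM and 100000 nM.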

Compound 4, concentration for total growth inhibition: > 100000 nM
Compound 4: no number, only a limit; the forecaster's own chance of this, stated with the estimate: 35%; at least 5.0-fold (0.69 log units) between middle value and limit.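

In this assay compound 4 gives > 100000 nM, which is a limit of the assay. Compound 3 sits at a limit as well, so the step between compound 3 and compound 4 cannot be read. The compounds shown leave open whether methoxy in place of hydrogen changes growth inhibition at all on the core of compound 3.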